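Replacing 2-methylphenyl with 4-methoxyphenyl on the shared core

A few compounds are considered here, and "the series" means these few. Any claim that something is new, unique, unknown or untested is made for them only; others in the source may bear on it.

Compound 2 `Cc1ccccc1Nc1nc2nonc2nc1Nc1ccccc1F` sits highest of the two numbers in an assay on mitochondria from L6 cells (Rattus norvegicus) for activation, with a stated time of 90 min (a lower number here means that less compound is needed, a higher number that more compound is needed for the effect), giving 1100 nM, while compound 1 `Fc1ccccc1Nc1nc2nonc2nc1Nc1cccc(F)c1F` gives 500 nM. Within the data shown here, the one step in hand, a 2.2-fold higher number from compound 1 to compound 2 (0.34 log units; beyond the scatter), concerns a different group and bears only loosely on the new change. Compound 3 `COc1ccc(Nc2nc3nonc3nc2Nc2ccccc2F)cc1` differs from compound 2 as follows: 4-methoxyphenyl in place of 2-methylphenyl on a nitrogen on an aromatic ring. Among the measured compounds shown here, with no step that shows this exchange, the expected change a 1.4-fold higher number from compound 2 to compound 3 (0.13 log units; within the scatter) is small, in either direction. Compound 3 is therefore estimated at 1500 nM, within a range from 500 nM to 4500 nM.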

Compound 3, half-maximal effective concentration: 1600 nM
Compound 3: middle estimate off by 1.1-fold (0.03 log units), on the low side, within the range that was stated.
By their numbers in this assay, from the lowest: compound 1; then compounds 2 and 3 (each within the scatter of the next).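

In this assay, 4-methoxyphenyl in place of 2-methylphenyl on a nitrogen on an aromatic ring gives a 1.5-fold higher number from compound 2 to compound 3 (0.16 log units; within the scatter), so these two groups cannot be told apart here, although the entering group brings an oxygen and a hydrogen-bond acceptor. Set against 2,3-difluorophenyl, 4-methoxyphenyl gives a 3.2-fold higher number from compound 1 to compound 3 (0.51 log units; beyond the scatter), which leaves 2,3-difluorophenyl as the one group at this position that stands apart from the others shown. Nothing available explains these numbers. Still open, on these data alone, is how an amine or a carboxylic acid on this phenyl ring would fare, or a longer chain in its place.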